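Swapping the aryl cap for a pyrimidine: cytotoxicity expectation

The source may hold more compounds than are shown below. What is called first, only, known or untested is meant among the compounds shown, and "the series" means these compounds.

Measured so far in an ADME assay on HeLa cells (Homo sapiens) for cytotoxicity, read by ATP content, with a stated time of 3 days; on this read-out higher numbers stand for lower toxicity in this test and lower numbers for higher toxicity in this test:
- compound 1 `O=c1n(Cc2nc3nc(Cl)ccc3n2CCCCO)c2cnccc2n1C1CC1` gives > 50000 nM, a limit of the test.
- compound 2 `N#CCCCn1c(Cn2c(=O)n(-c3ccc(C(=O)NC4CC4)cc3)c3ccncc32)cc2cc(Cl)ccc21` gives > 50000 nM, a limit of the test.
- compound 3 `O=c1n(Cc2cc3ccc(Cl)cc3n2CCCCO)c2cnccc2n1C1CC1` gives > 50000 nM, a limit of the test.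

Compound 2 stands at the same limit as the other two, so no ordering among them can be read; all three share (the limit of > 50000 nM in this assay, at which 3 of the 3 values shown sit).

Compound 4 `N#CCCCn1c(Cn2c(=O)n(-c3ncccn3)c3ccncc32)cc2cc(Cl)ccc21` differs from compound 2 in one place: pyrimidin-2-yl in place of 4-(cyclopropylcarbamoyl)phenyl on an aromatic nitrogen. Within the data shown here, no step between measured compounds is available, so the expectation rests on the three shared limits. The step from compound 2 to compound 4 is expected to be none beyond the scatter, a number no higher from compound 2 to compound 4 (the limit leaves the size open). Compound 4 is estimated at 50000 nM, from 20000 nM to 100000 nM, most likely again reported only as a limit.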

Compound 4, half-maximal cytotoxic concentration: > 50000 nM
Compound 4: a limit, no number; the forecaster's own chance of this, stated with the estimate: 75%; the middle value sits exactly at the limit.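

In this assay compound 4 gives > 50000 nM, a limit of the test. Compound 2 stands at that same limit, so no step can be read between compound 2 and compound 4. The compounds shown leave open any ordering among them in this assay: the limit of > 50000 nM in this assay, at which 4 of the 4 values shown sit.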